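The source may hold more compounds than are shown below. What is called first, only, known or untested is meant among the compounds shown, and "the series" means these compounds.

Values in an ADME assay on Caco-2 cells (Homo sapiens) for permeability, read by LC-MS, in the apical to basolateral direction, with a stated time of 60 min, at pH 6.5; a lower number here means that the compound crosses the layer more slowly, a higher number that the compound crosses the layer faster:
- compound 1 `O=C(NCc1cc(Cl)ccc1-n1cnnn1)[C@@H]1CC=NN1C(=O)[C@H](O)c1ccccc1F`: 8.9 10^-6 cm/s
- compound 2 `O=C(NCc1cc(Cl)ccc1-n1cnnn1)[C@@H]1CC=NN1C(=O)[C@H](O)Cc1ccccc1`: 11 10^-6 cm/s
- compound 3 `CC(C)(C)C[C@@H](O)C(=O)N1[C@H](C(=O)NCc2cc(Cl)ccc2-n2cnnn2)C[C@@H]2C[C@@H]21`: 25 10^-6 cm/s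

Compound 2 lies within the scatter of compound 1, and compound 3 stands above it, beyond the scatter. The next compound to be read is compound 4 `O=C(NCc1cc(Cl)ccc1-n1cnnn1)[C@@H]1CC=NN1C(=O)[C@H](O)C1CCCCC1`, with this change from compound 2: cyclohexyl in place of benzyl on a saturated chain carbon bound to a carbonyl carbon and an oxygen on a saturated carbon. In words, cyclohexyl takes the place of benzyl on a saturated chain carbon bound to a carbonyl carbon and an oxygen on a saturated carbon.

Among the measured compounds shown here, only one measured step bears on this place: a 1.2-fold higher number from compound 1 to compound 2 (0.09 log units; within the scatter). That exchange of 2-fluorophenyl for benzyl stayed within the scatter. For the measured compounds named here, compound 3 differs from compound 2 in more than one place, so it gives no direct step for this change. Going by the values given here, no measured compound pairs benzyl with cyclohexyl.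

With so little evidence, no shift beyond the scatter is expected in this assay. The expected step is a 1.2-fold higher number from compound 2 to compound 4 (0.07 log units; within the scatter). The estimate for compound 4 is 13 10^-6 cm/s, with an expected range of 6.5 10^-6 cm/s to 26 10^-6 cm/s.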

Compound 4, apparent permeability: 19 10^-6 cm/s
Compound 4: middle estimate off by 1.5-fold (0.16 log units), on the low side; the range from low to high includes it.
By their numbers in this assay, from the lowest: compounds 1, 2, 4 and 3 (each within the scatter of the next, the first and the last beyond it).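

Cyclohexyl on this saturated chain carbon gives the first step at this position to pass the scatter, though only modestly, when it takes the place of 2-fluorophenyl (a 2.1-fold higher number from compound 1 to compound 4 (0.33 log units; beyond the scatter)). Against benzyl, the same group gives no separable difference in this assay (a 1.7-fold higher number from compound 2 to compound 4 (0.24 log units; within the scatter)), so an aromatic ring on this carbon or one step further out is not required to keep the number in this range among compound 1, compound 2 and compound 4. No measurement at hand accounts for either step.

Open, as far as these compounds go, is how this position responds to a group carrying nitrogen or oxygen, such as an amine, a carboxylic acid or a morpholine ring. Also open, from the compounds shown here alone, are unsubstituted phenyl, which would separate the fluorine from the ring, and a longer chain.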